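The source may report more compounds than this note shows. Statements on the series, on what has been measured and on what is new or still open speak of the compounds shown alone.

Measured so far:
compound 1 `CCCN(CC[C@H]1CC[C@H](NC(=O)c2ccc3ccccc3n2)CC1)[C@H]1CCc2nc(N)sc2C1` gives 1.6 nM
compound 2 `CCCN(CC[C@H]1CC[C@H](NC(=O)c2cccc3ncccc23)CC1)[C@H]1CCc2nc(N)sc2C1` gives 1.6 nM

Both numbers come from an assay on brain for displacement of a labelled ligand from D(3) dopamine receptor (Rattus norvegicus); on this read-out higher numbers stand for weaker inhibition and lower numbers for stronger inhibition. Compound 2 stands level with compound 1 on this read-out, as the step of no change at the digits printed from compound 1 to compound 2 (within the scatter) shows no change beyond the scatter, even though the two compounds carry different two-ring aromatic groups on the carbonyl carbon of the amide.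

The compound still to be measured is compound 3 `CCCN(CC[C@H]1CC[C@H](NC(=O)c2cccc3cnccc23)CC1)[C@H]1CCc2nc(N)sc2C1`. It differs from compound 2 in one place: isoquinolin-5-yl in place of quinolin-5-yl on a carbonyl carbon. The two groups are built from the same atoms, joined differently, so the change is again a swap of one two-ring aromatic group for another of the same size on the same carbonyl carbon.

Among the measured compounds shown here, only one measured step bears on such a swap, the one from compound 1 to compound 2, and it produced no change within the scatter. On that basis no shift beyond the scatter is expected in this assay in either direction, and compound 3 is estimated at 2 nM, with a range from 0.6 nM to 6 nM, an expected step of a 1.3-fold higher number from compound 2 to compound 3 (0.10 log units; within the scatter).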

Compound 3, inhibition constant: 5.9 nM
Compound 3: the middle estimate sits 3.0-fold (0.47 log units) below what was measured; the range from low to high includes it.
By their numbers in this assay, from the lowest: compounds 1 and 2 (each within the scatter of the next); then compound 3.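

Compounds 1 and 2 left the impression that one two-ring aromatic group could replace another on this carbonyl carbon with no effect on the number. The new compound shows that this does not hold for every such swap: in this assay isoquinolin-5-yl in place of quinolin-5-yl gives a 3.7-fold higher number from compound 2 to compound 3 (0.57 log units; beyond the scatter) and isoquinolin-5-yl in place of quinolin-2-yl gives a 3.7-fold higher number from compound 1 to compound 3 (0.57 log units; beyond the scatter) and both steps are modest. The leaving and entering groups have the same atoms and the same ring, donor and acceptor counts, so the way those atoms are joined is enough on its own to move the number beyond the scatter, and no measurement offered here accounts for why this swap shifts it when the step between the two quinoline groups did not.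

The compounds shown leave open whether the ring nitrogen is needed at all on this carbonyl carbon, a question that a naphthyl group, with carbon atoms only in both rings, would address. They also leave open whether a single-ring group such as phenyl or pyridyl would keep the number level with compound 1 or move it further.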